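Aryl swap on the shared core, single-point inhibition

The source may report more compounds than this note shows. Statements on the series, on what has been measured and on what is new or still open speak of the compounds shown alone.

In a functional assay for inhibition, tested at 20 ug/mL (a lower number here means a weaker effect, a higher number a stronger effect of the compound at the concentration tested), compound 1 `COc1ccc(-c2cc(-c3cc(C(C)C)c(O)cc3C)[nH]c(=O)c2C#N)cc1` gives 24% and compound 2 `COc1cc(-c2cc(-c3cc(C(C)C)c(O)cc3C)[nH]c(=O)c2C#N)ccc1O` gives 26%. Between these two there is a number 2 percentage points higher from compound 1 to compound 2 (within the scatter). Compound 2 therefore stands level with compound 1 in this assay, with no separation beyond the scatter. Compound 3 `Cc1cc(O)c(C(C)C)cc1-c1cc(-c2ccc(N(C)C)cc2)c(C#N)c(=O)[nH]1` differs from compound 2 at the same aromatic carbon: 4-(dimethylamino)phenyl in place of 4-hydroxy-3-methoxyphenyl on an aromatic carbon. Among the measured compounds shown here, the only measured step bearing on this position is a number 2 percentage points higher from compound 1 to compound 2 (within the scatter), which stayed within the scatter, so in this assay no step beyond the scatter is expected for compound 3, a number 1 percentage points lower from compound 2 to compound 3 (within the scatter). Compound 3 is estimated at 25%, with a range from 10% to 40%.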

Compound 3, a percentage reported as inhibition, at one concentration (the size of the read-out at that concentration, not a potency): 30%
For compound 3 the middle estimate is 5 percentage points below the measured one; measured number inside the range.
By their numbers in this assay, from the lowest: compounds 1, 2 and 3 (each within the scatter of the next).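

In this assay, the position opposite the ring nitrogen now carries a nitrogen-bearing aryl group as well as oxygen-bearing ones, with no separation: a number 4 percentage points higher from compound 2 to compound 3 (within the scatter), and a number 6 percentage points higher from compound 1 to compound 3 (within the scatter). Exchanging methoxy for dimethylamino, or losing the hydrogen-bond donor of 4-hydroxy-3-methoxyphenyl, therefore gives no step beyond the scatter at this single concentration. Nothing available speaks to a cause for these numbers.

Open, going by these compounds, is whether an unsubstituted phenyl, or a phenyl bearing a carboxylic acid, would move the read-out beyond the scatter. Potency also remains open, as these are single-concentration percentages.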